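Changing the Fluorine Pattern on the Chain-End Ring

The source may report more compounds than this note shows. Statements on the series, on what has been measured and on what is new or still open speak of the compounds shown alone.

Of the compounds shown here, three sharing one core have been measured in a functional assay on HEK293 cells for antagonist activity at cysteinyl leukotriene receptor 2 (Homo sapiens), read by fluorescence and calcium flux, with stated times of 30 min and 1 h; on this read-out lower numbers stand for stronger inhibition and higher numbers for weaker inhibition. Compound 1 `Cc1c(CCCC(=O)O)c2cccc(/C=C/c3ccc(OCCCCc4ccccc4)cc3)c2n1CC(=O)O` gives 4.7 nM. Compound 2 `Cc1c(CCCC(=O)O)c2cccc(/C=C/c3ccc(OCCCCc4c(F)c(F)cc(F)c4F)cc3)c2n1CC(=O)O`, which carries 2,3,5,6-tetrafluorophenyl in place of phenyl on a saturated chain carbon, four bonds along the chain from an oxygen on an aromatic ring, gives 3.7 nM. Compound 3 `Cc1c(F)cccc1CCCCOc1ccc(/C=C/c2cccc3c(CCCC(=O)O)c(C)n(CC(=O)O)c23)cc1` gives 7.2 nM. Among these three numbers compound 3 stands highest, yet its distance to either of the others is within the scatter: a 1.5-fold higher number from compound 1 to compound 3 (0.19 log units; within the scatter) and a 1.9-fold higher number from compound 2 to compound 3 (0.29 log units; within the scatter).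

Compound 4 `Cc1c(CCCC(=O)O)c2cccc(/C=C/c3ccc(OCCCCc4c(F)ccc(F)c4F)cc3)c2n1CC(=O)O` has not yet been measured in this assay. It differs from compound 3 in one place: 2,3,6-trifluorophenyl in place of 3-fluoro-2-methylphenyl on a saturated chain carbon, four bonds along the chain from an oxygen on an aromatic ring

The measured steps that bear on this all exchange the aromatic group at the end of the chain. a 1.3-fold lower number from compound 1 to compound 2 (0.10 log units; within the scatter); likewise a 1.5-fold higher number from compound 1 to compound 3 (0.19 log units; within the scatter). None of the three exchanges moved the number beyond the scatter. Because a 1.3-fold lower number from compound 1 to compound 2 (0.10 log units; within the scatter) and a 1.9-fold higher number from compound 2 to compound 3 (0.29 log units; within the scatter) both stayed within the scatter, the step from compound 3 to compound 4 is expected to be a 1.6-fold lower number from compound 3 to compound 4 (0.20 log units; within the scatter), that is, no movement that can be told from repeat measurement. Compound 4 is therefore estimated at 4.5 nM, with an expected range from 2 nM to 10 nM.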

Compound 4, half-maximal inhibitory concentration: 1 nM
Compound 4: the middle estimate sits 4.5-fold (0.65 log units) above what was measured; measured number below the stated range.
By their numbers in this assay, from the lowest: compound 4; then compounds 2, 1 and 3 (each within the scatter of the next).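

In this assay, among these compounds, exchanging the ring at the end of the chain now moves the number beyond the scatter for the first time: 2,3,6-trifluorophenyl gives a 7.2-fold lower number from compound 3 to compound 4 (0.86 log units; beyond the scatter) and a 4.7-fold lower number from compound 1 to compound 4 (0.67 log units; beyond the scatter). A single ring fluorine also proves to matter, as hydrogen in place of fluoro on an aromatic carbon, which turns 2,3,5,6-tetrafluorophenyl into 2,3,6-trifluorophenyl, gives a 3.7-fold lower number from compound 2 to compound 4 (0.57 log units; beyond the scatter), so the number does not simply follow the count of fluorines: the ring with none and the ring with four remain within the scatter of each other, with a 1.3-fold lower number from compound 1 to compound 2 (0.10 log units; within the scatter), while the ring with three stands apart from both. Nothing measured here explains why this fluorine pattern gives the lowest number of the four.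

As far as these compounds go, it remains open whether the gain belongs to this exact arrangement or would also appear with another, such as 2,4,6-trifluorophenyl, or with chlorine atoms in place of the three fluorines. From the compounds shown here alone, it is also open whether 2,3,6-trifluorophenyl would keep its advantage at the end of a longer chain.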